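Replacing the side chain of compound 2

A few compounds are considered here, and "the series" means these few. Any claim that something is new, unique, unknown or untested is made for them only; others in the source may bear on it.

Compound 1 `CCC(CC)Nc1nc(OC)c(-c2ccc(Cl)cc2Cl)nc1C`: 0.283 h
Compound 2 `CCc1nc(-c2ccc(Cl)cc2Cl)c(CC)nc1NC(COC)COC`: 0.0417 h
Compound 3 `CCC(CC)Nc1nc(C)c(-c2ccc(Cl)cc2Cl)nc1C`: 0.0533 h

All three were measured in an in vitro ADME assay on microsomes (Rattus norvegicus) for metabolic stability; on this read-out lower numbers stand for a shorter-lived compound and higher numbers for a longer-lived compound. Compound 2 gives 0.0417 h, a number within the scatter of that of compound 3 and clearly lower than that of compound 1. The next compound, compound 4 `CCc1nc(-c2ccc(Cl)cc2Cl)c(CC)nc1SC(C)CC`, differs from compound 2 in one place: (sec-butyl)sulfanyl in place of (2-methoxy-1-(methoxymethyl)ethyl)amino on an aromatic carbon. Among the compounds with values here, the only measured step between close neighbours is a 5.3-fold lower number from compound 1 to compound 3 (0.73 log units; beyond the scatter), which exchanges methoxy for methyl on an aromatic carbon. Within the data shown here, that step lies beyond the scatter, but it concerns a different group, and no measured step touches the (2-methoxy-1-(methoxymethyl)ethyl)amino group. It therefore gives no direction for this change and shows only how far one exchange moved the number in this assay. The expectation rests on compound 2 at 0.0417 h, with no shift beyond the scatter expected. The expected outcome is a 1.2-fold higher number from compound 2 to compound 4 (0.08 log units; within the scatter). The estimated half-life of compound 4 is 0.05 h, with an expected range of 0.02 h to 0.15 h.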

Compound 4, half-life: 0.0683 h
Compound 4: middle estimate off by 1.4-fold (0.14 log units), on the low side, and the stated range covers the measured number.
By their numbers in this assay, from the lowest: compounds 2, 3 and 4 (each within the scatter of the next); then compound 1.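

Within the data shown here, the position on an aromatic carbon next to the ring nitrogen, para to the 2,4-dichlorophenyl group, had not been varied among the earlier compounds, and this pair is the first reading of it. Exchanging (2-methoxy-1-(methoxymethyl)ethyl)amino for (sec-butyl)sulfanyl comes to a 1.6-fold higher number from compound 2 to compound 4 (0.21 log units; within the scatter) in this assay and so leaves compound 2 and compound 4 indistinguishable, even though the linking atom, both methoxy groups and the hydrogen-bond donor all leave together. No measurement on hand explains why the number holds across so large an exchange.

The compounds shown leave open whether a morpholine or a longer alkyl chain on the sulfur at this position would move the number beyond the scatter. They also leave open whether an oxygen-linked sec-butyl group would behave as the sulfur-linked one does.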